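Urea series: removing one trifluoromethyl on the terminal aryl

The source may hold more compounds than are shown below. What is called first, only, known or untested is meant among the compounds shown, and "the series" means these compounds.

Measured so far in a functional assay on NCI/ADR-RES cells (Homo sapiens) for inhibition, read by sulforhodamine B assay, with a stated time of 48 h, tested at 100 uM; a lower number here means a stronger effect, a higher number a weaker effect of the compound at the concentration tested:
- compound 1, `O=C(Nc1cccc(-n2cc(-c3ccncc3)c(-c3cc(O)cc(Cl)c3)n2)c1)Nc1ccc(Cl)c(Cl)c1`: 2%
- compound 2, `COc1cc(Cl)cc(-c2nn(-c3cccc(NC(=O)Nc4cc(C(F)(F)F)cc(C(F)(F)F)c4)c3)cc2-c2ccncc2)c1`: -12%

Compound 2 stands at the lowest of the two numbers in this assay . For the measured compounds named here, its nearest neighbour is compound 1, which reads a number higher, and the gap between the two lies beyond the scatter; no single-point step between them is computed, so their two values are taken as they stand.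

Compound 3, `COc1cc(Cl)cc(-c2nn(-c3cccc(NC(=O)Nc4cccc(C(F)(F)F)c4)c3)cc2-c2ccncc2)c1`, has not been measured in this assay . It differs from compound 2 as follows: hydrogen in place of trifluoromethyl on an aromatic carbon. One trifluoromethyl on the terminal aryl of the urea is gone; the other remains.

Going by the values given here, no measured pair shows a step of this kind, so the size of the change is open. Compound 3 is expected to stay close to compound 2, with the step from compound 2 to compound 3 estimated as a number 7 percentage points higher from compound 2 to compound 3 (within the scatter), a shift not beyond the scatter. Compound 3 is therefore estimated at -5%, within a range of -30% to 25%.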

Compound 3, a percentage reported as activity, at one concentration (the size of the read-out at that concentration, not a potency): -22%
For compound 3 the middle estimate is 17 percentage points above the measured one; low and high end bracket the measured number.
By their numbers in this assay, from the lowest: compounds 3 and 2 (each within the scatter of the next); then compound 1.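

In this assay, for the compounds shown here, the step of a number 10 percentage points lower from compound 2 to compound 3 (within the scatter) is the first single-place comparison available, and it stays within the scatter. At this position on the terminal aryl of the urea, hydrogen can therefore stand in place of one trifluoromethyl with no measurable change in the read-out at the concentration tested, so compound 2, with both trifluoromethyl groups, and compound 3, with one, cannot be told apart here. No measurement at hand bears on a cause for this result.

On these data alone, whether the remaining trifluoromethyl is needed stays open, as does the outcome of putting a nitrile, an amine or a carboxylic acid on this aromatic carbon in its place. Compound 1 differs from compound 3 in more than one place, so it says nothing about this position, and a single concentration leaves any difference in potency between compound 2 and compound 3 unresolved.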